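Swapping the styryl arm for 4-chlorophenyl

The source may report more compounds than this note shows. Statements on the series, on what has been measured and on what is new or still open speak of the compounds shown alone.

compound 1 `C(=C/c1nc2ccccn2c1Sc1ccccc1)\c1ccccc1` gives 22000 nM
compound 2 `Cc1ccc(-c2nc3ccc(C)cn3c2Sc2ccccc2)cc1` gives 57700 nM
compound 3 `CS(=O)(=O)c1ccc(-c2nc3ccccn3c2Sc2cccc3ccccc23)cc1` gives 20800 nM

These numbers come from a functional assay on DU-145 cells (Homo sapiens) for inhibition, read by MTT assay, with a stated time of 48 h (on this read-out lower numbers stand for stronger inhibition and higher numbers for weaker inhibition), and all three compounds are weak on this scale. Compound 1 stands level with compound 3 within the usual scatter, while compound 2 has a higher number, beyond the scatter.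

Compound 4 `Clc1ccc(-c2nc3ccccn3c2Sc2ccccc2)cc1` keeps the core and the phenylsulfanyl group of compound 1 but has 4-chlorophenyl in place of 2-phenylethenyl on an aromatic carbon in its structure.

Among the measured compounds shown here, no two measured compounds differ in one place only, so this change has no measured precedent. Compound 2 (57700 nM) and compound 3 (20800 nM) also carry a six-membered aromatic ring of carbon only at that place, and their values give a rough frame. The estimated 1.4-fold higher number from compound 1 to compound 4 (0.13 log units; within the scatter) is expected to be small and upward, with nothing beyond the scatter. Compound 4 is expected at 30000 nM within an estimated range of 12000 nM to 70000 nM in this assay when it is measured.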

Compound 4, half-maximal inhibitory concentration: 30700 nM
Compound 4: middle estimate off by 1.0-fold (0.01 log units), on the low side; the measured number falls inside the stated range.
By their numbers in this assay, from the lowest: compounds 3, 1, 4 and 2 (each within the scatter of the next, the first and the last beyond it).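

Among the compounds shown here, the step of a 1.4-fold higher number from compound 1 to compound 4 (0.14 log units; within the scatter) is the first single-place change that can be read at this aromatic carbon in this assay. It shows that 2-phenylethenyl can give way to 4-chlorophenyl without a change that stands out from the usual scatter, even though the double bond outside the aromatic rings is lost and a chlorine is gained. These two differences arrive together, so this step cannot judge either one alone, and nothing measured here speaks to the reason for the result.

For the compounds shown here, every group seen at this place so far carries a six-membered aromatic ring of carbon only, so it remains open whether a group without such a ring, such as an amine or a carboxylic acid, would give a similar number. A plain phenyl group, without the chlorine, would help separate the two differences.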